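The source may hold more compounds than are shown below. What is called first, only, known or untested is meant among the compounds shown, and "the series" means these compounds.

The measured compounds and their values in a functional assay on the whole organism (strain albino) for inhibition, with Rattus norvegicus as the target, read by paw edema, with stated times of 30 min and 3 h, at a dose of 100 mg/kg by the oral route; a higher number here means more inhibition at the dose given (going by the name of the read-out), a lower number less inhibition:

Compound 1, `O=C(CBr)Nc1ccc(C(=O)/C=C/c2ccco2)cc1`, gives 41%.
Compound 2, `O=C(CO[N+](=O)[O-])Nc1ccc(C(=O)/C=C/c2ccc(Cl)cc2)cc1`, gives 69%.
Compound 3, `COc1ccc(/C=C/C(=O)c2ccc(NC(=O)CO[N+](=O)[O-])cc2)cc1`, gives 53%.

Compound 3 stands second of the three in this assay: compound 1 lies below it, beyond the scatter, and compound 2 lies above it, again beyond the scatter. The one measured step among these compounds is the change from compound 2 to compound 3, a number 16 percentage points lower from compound 2 to compound 3 (beyond the scatter).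

Compound 4, `O=C(CO[N+](=O)[O-])Nc1ccc(C(=O)/C=C/c2ccco2)cc1`, has not been measured in this assay. Its change from compound 3 is furan-2-yl in place of 4-methoxyphenyl on a double-bonded chain carbon bound to a double-bonded chain carbon. Going by the values given here, no measured step shows this exchange on its own. Compound 1 shares the furan-2-yl group with compound 4 but differs at the amide side chain, so its value can only be read as a loose pointer to where a furan-bearing compound of this series may fall. Given that compound 1 sits below compound 3, and that no step bears directly on this exchange, compound 4 is expected to land somewhat below compound 3, with a step of a number 7 percentage points lower from compound 3 to compound 4 (within the scatter) that may well stay within the scatter. Compound 4 is estimated at 46%, with a range from 30% to 62%.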

Compound 4, a percentage reported as inhibition, in the whole organism at one dose (the size of the read-out at that dose, not a potency): 48%
Compound 4: middle estimate off by 2 percentage points, on the low side; low and high end bracket the measured number.
By their numbers in this assay, from the lowest: compounds 1, 4 and 3 (each within the scatter of the next, the first and the last beyond it); then compound 2.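

In this assay, furan-2-yl in place of 4-methoxyphenyl on a double-bonded chain carbon bound to a double-bonded chain carbon gives a number 5 percentage points lower from compound 3 to compound 4 (within the scatter) and so leaves the two groups unseparated, while furan-2-yl in place of 4-chlorophenyl at the same place gives a number 21 percentage points lower from compound 2 to compound 4 (beyond the scatter) as a step that stands clear of the noise. On the saturated chain carbon bound to a carbonyl carbon, nitrooxy in place of bromo gives a number 7 percentage points higher from compound 1 to compound 4 (within the scatter) and so does not separate these two groups on the furan-2-yl compounds. Nothing available explains any of these steps.

On these data alone, it remains open how a thiophene ring or a 4-fluorophenyl group would read at the double-bonded chain carbon. Also open, as far as these compounds go, is how an amine or a hydroxyl group would read in place of nitrooxy on the saturated chain carbon.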